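The compounds below may be only part of what the source reports. "The series", "measured", "known", "first", "only" and "open" are said of these compounds alone.

The series shares one core: compound 1 `FC(F)(F)c1ccc(CN2CCN(Cc3cc(-c4ccc(OCc5ccccc5Cl)cc4)on3)CC2)cc1`, compound 2 `FC(F)(F)c1ccc(CN2CCN(Cc3cc(-c4ccc(OCc5cccc(Cl)c5)cc4)on3)CC2)cc1` and compound 3 `N#Cc1cccc(COc2ccc(-c3cc(CN4CCN(c5ccc(C(F)(F)F)cn5)CC4)no3)cc2)c1` differ only in the groups at either end of it. Among the measured compounds shown here, in a functional assay on MCF7 cells (Homo sapiens) for antiproliferative activity, read by sulforhodamine B assay, with a stated time of 72 h (a lower number here means a stronger inhibitor, a higher number a weaker inhibitor), compound 1 gives 2800 nM and compound 2 gives 1400 nM; the single recorded step, a 2.0-fold lower number from compound 1 to compound 2 (0.30 log units; within the scatter), is the only measured change in the set. Compound 3 gives 1400 nM in this assay, level with compound 2 at the digits shown and together with it the lowest of the three numbers, with compound 1 the furthest, though the gap to compound 1 is within the scatter and no order is claimed.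

Compound 4 `N#Cc1cccc(COc2ccc(-c3cc(CN4CCN(C(=O)C5CCCO5)CC4)no3)cc2)c1` is the unmeasured member. The change from compound 3 is (oxolan-2-yl)carbonyl in place of 5-(trifluoromethyl)pyridin-2-yl on an amine nitrogen in a ring. For the measured compounds named here, no measured step touches this position: the one step in the set, a 2.0-fold lower number from compound 1 to compound 2 (0.30 log units; within the scatter), concerns the chlorophenyl on the saturated chain carbon bound to the oxygen and says nothing about the amine nitrogen in the ring. The expectation for this assay therefore rests on compound 3 at 1400 nM alone, as no change at the digits printed from compound 3 to compound 4 (within the scatter), with no direction assumed beyond the scatter and a wide range. Compound 4 is estimated at 1400 nM, expected between 350 nM and 5600 nM.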

Compound 4, half-maximal inhibitory concentration: 3800 nM
Beside the measured number, compound 4's estimate is 2.7-fold (0.43 log units) below it; measured number inside the range.
By their numbers in this assay, from the lowest: compounds 2, 3, 1 and 4 (each within the scatter of the next, the first and the last beyond it).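

The amine nitrogen in the ring is now shown to be a position that moves the number in this assay (a step of a 2.7-fold higher number from compound 3 to compound 4 (0.43 log units; beyond the scatter)), and this is the only step in the set that lies beyond the scatter. The position also accepts a non-aromatic acyl group in place of an aromatic ring, at a modest cost: (oxolan-2-yl)carbonyl, with its five-membered non-aromatic ring and a double bond outside aromatic rings, replaces 5-(trifluoromethyl)pyridin-2-yl, and compound 4 still gives a measurable number (3800 nM). The swap alters the ring, the carbonyl and the fluorine content in one move, and no measurement available here accounts for the higher number.

Which of these parts carries the step stays open: an acetyl or a benzoyl on the same nitrogen would separate the carbonyl from the ring that follows it, and a plain pyridin-2-yl would isolate the trifluoromethyl. Also open, as far as these compounds go, is whether the step holds with the 3-chlorophenyl end of compound 2 in place of the nitrile-bearing end of compounds 3 and 4.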